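The compounds below may be only part of what the source reports. "The series", "measured", "known", "first", "only" and "open" are said of these compounds alone.

Among the compounds with values here, in a functional assay on MCF7 cells (Homo sapiens) for inhibition, read by sulforhodamine B assay (on this read-out higher numbers stand for weaker inhibition of growth and lower numbers for stronger inhibition of growth), compound 1 (`Cc1ccc2[nH]c(-c3ccc(-c4ccc(-c5cccc(Cl)c5)cc4)cc3)nc2c1`) gives 1210 nM, the lowest of the three numbers so far, against 36300 nM for compound 2 (`Clc1cccc(-c2ccc(-c3ccc(-c4nc5ccccc5[nH]4)cc3)cc2)c1`) and 3010 nM for compound 3 (`Oc1cccc2[nH]c(-c3ccc(-c4ccc(-c5ccc(F)cc5)cc4)cc3)nc12`). Compound 4 (`Cc1ccc2[nH]c(-c3ccc(-c4ccc(-c5ccc(OC(F)(F)F)cc5)cc4)cc3)nc2c1`) has 4-(trifluoromethoxy)phenyl in place of 3-chlorophenyl on an aromatic carbon. Within the data shown here, the one measured step, a 30-fold higher number from compound 1 to compound 2 (1.48 log units; beyond the scatter), removes the methyl that compound 4 keeps, so it does not gauge this exchange. Another terminal ring appears in compound 3 at 3010 nM, though that compound also differs elsewhere. Only a small rise, not clearly beyond the scatter, is therefore expected in this assay: a 1.5-fold higher number from compound 1 to compound 4 (0.17 log units; within the scatter). For compound 4 the estimated value is 1800 nM, with an expected range from 600 nM to 5500 nM.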

Compound 4, concentration for 50% growth inhibition: 31000 nM
The estimate for compound 4 lay 17-fold (1.24 log units) below the measured number; measured number above the stated range.
By their numbers in this assay, from the lowest: compound 1; then compound 3; then compounds 4 and 2 (each within the scatter of the next).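

In this assay, the exchange on the terminal ring alone, with the methyl kept, gives a 26-fold higher number from compound 1 to compound 4 (1.41 log units; beyond the scatter) and so counts as a large step. Both this change and the loss of the methyl, which gives a 30-fold higher number from compound 1 to compound 2 (1.48 log units; beyond the scatter) in the same assay, are large steps away from compound 1, so the outer ring matters here as well as the core. Nothing measured here accounts for the loss of growth inhibition.

The step changes both the substituent and its place on the ring, so the two effects stay unseparated. A 4-chlorophenyl or an unsubstituted phenyl on the core of compound 1 would show which of them carries the loss.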